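A few compounds are considered here, and "the series" means these few. Any claim that something is new, unique, unknown or untested is made for them only; others in the source may bear on it.

Measured compounds:
compound 1 `Cc1cc(-c2ccc(C(F)(F)F)cc2)nn1S(=O)(=O)Oc1ccccc1` — 35.9%
compound 2 `CCc1ccc(-c2cc(C)n(S(=O)(=O)Oc3ccccc3)n2)cc1` — 21.1%

In a functional assay on the whole organism for inhibition, with Mus musculus as the target, with stated times of 3 days and 30 min, at a dose of 30 mg/kg by the oral route (a higher number here means more inhibition at the dose given (going by the name of the read-out), a lower number less inhibition), compound 2 gives 21.1%, the lower of the two numbers shown; compound 1 gives 35.9%, and the only measured step, a number 14.8 percentage points lower from compound 1 to compound 2 (beyond the scatter), lies beyond the scatter. Compound 3 `Cc1cc(-c2cccc(Cl)c2)nn1S(=O)(=O)Oc1ccccc1` carries 3-chlorophenyl in place of 4-ethylphenyl on an aromatic carbon. Among the compounds with values here, no measured step covers this exact exchange; the one known step shows that changing the group on this aryl ring can move the read-out modestly. Compound 3 is therefore expected to shift by a number 8.9 percentage points higher from compound 2 to compound 3 (within the scatter), landing near 30%, within 12% to 48%.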

Compound 3, a percentage reported as inhibition, in the whole organism at one dose (the size of the read-out at that dose, not a potency): 10%
The estimate for compound 3 lay 20 percentage points above the measured number; the measured number lies below the stated range.
By their numbers in this assay, from the lowest: compound 3; then compound 2; then compound 1.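

In this assay, 3-chlorophenyl in place of 4-ethylphenyl gives a number 11.1 percentage points lower from compound 2 to compound 3 (beyond the scatter). The aryl group at this position therefore spans a wider range than the first pair showed, with compound 1 at 35.9% and compound 3 at 10%. No measurement shown accounts for this drop. Because the exchange alters both the substituent and its place on the phenyl ring, the compounds shown leave open which of the two matters. They also leave open how a phenyl ring carrying an amine or a carboxylic acid would read.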